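This account rests on a few compounds, and the source may have more. Where it says the series, first, only, none or still open, it means among the compounds named here.

Measured so far:
- compound 1, `CSc1cnc2ccccc2c1[Se]CC#CCOC(=O)c1ccc(C(=O)O)cc1`: 3.1 ug/mL
- compound 2, `ClCC#CCSc1cnc2ccccc2c1Cl`: 4 ug/mL
- compound 3, `OCC#CCSc1cnc2ccccc2c1SCC#CCCl`: 43.4 ug/mL

All three were tested in a functional assay on B16 cells (Mus musculus) for antiproliferative activity, with a stated time of 72 h; a higher number here means a weaker inhibitor, a lower number a stronger inhibitor. Compound 1 gives the lowest of the three numbers. Its neighbour is compound 2, whose value lies so close that the two cannot be told apart by this measurement. Compound 3, by contrast, sits far higher, well beyond the ordinary scatter, so it is clearly the weaker inhibitor of the set. Among the compounds with values here, no pair of these measured compounds differs in only one place, so no single structural step has a measured effect here.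

The new compound is compound 4, `CSc1cnc2ccccc2c1[Se]CC#CCOC(=O)/C=C/c1ccccc1`. It is built from compound 1 by one exchange on the ester end of the chain: 2-phenylethenyl in place of 4-carboxyphenyl on a carbonyl carbon. The rest of the shared core, including the selenium-linked chain, is untouched.

Within the data shown here, with no measured step to lean on, the expectation rests on compound 1 alone. The step from compound 1 to compound 4 is expected to be small, most likely within the usual scatter, with no strong reason to expect movement in either direction: a 1.2-fold lower number from compound 1 to compound 4 (0.09 log units; within the scatter). Compound 4 is therefore estimated at 2.5 ug/mL in this assay, with a plausible range from 0.8 ug/mL to 8 ug/mL.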

Compound 4, concentration for 50% inhibition: 3.1 ug/mL
Beside the measured number, compound 4's estimate is 1.2-fold (0.09 log units) below it; the measured number falls inside the stated range.
By their numbers in this assay, from the lowest: compounds 1, 4 and 2 (each within the scatter of the next); then compound 3.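

In this assay, within the data shown here, putting 2-phenylethenyl in place of 4-carboxyphenyl on a carbonyl carbon gives no change at the digits printed from compound 1 to compound 4 (within the scatter), the first measured step in this set in which only one place differs. The group that leaves carries 1 hydrogen-bond donor and 1 hydrogen-bond acceptor and the group that enters carries 0 of each, while both hold one six-membered aromatic ring of carbon only, so for this pair, losing that donor and acceptor leaves the number within the scatter. Among these compounds, no measurement in hand explains why the number holds, so this result records only that the exchange left the antiproliferative read-out within the scatter, not what happens inside the cells.

Going by these compounds, both groups at this position contain the same kind of aromatic ring, so it remains open whether the number would hold with a plain methyl group or a long saturated carbon chain on the carbonyl carbon, where that ring is absent. On these data alone, it is also open whether an amine on the aromatic ring would fit as well as the carboxylic acid of compound 1 does.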